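The source may report more compounds than this note shows. Statements on the series, on what has been measured and on what is new or still open speak of the compounds shown alone.

Compound 1 `Cc1ccc(C(=O)Nc2ccc3nc(NC(=O)C4CCCCC4)sc3c2)cc1`, compound 2 `O=C(Nc1ccc2nc(NC(=O)C3CCCCC3)sc2c1)c1ccc(Br)cc1` and compound 3 `CCCC(=O)Nc1nc2ccc(NC(=O)c3c(Cl)cccc3Cl)cc2s1` share one core and differ only in their two acyl groups. In a functional assay on WI-38 VA13 cells (Homo sapiens) for cytotoxicity (a lower number here means that less compound is needed, a higher number that more compound is needed for the effect), compound 1 gives 5.1 ug/mL. For compound 2 only a limit is reached, > 4 ug/mL. The step that the limit leaves unreadable from compound 1 to compound 2 is thus unreadable because of the limit of > 4 ug/mL in this assay, at which 1 of the 3 values shown sits. Compound 3 gives 0.01 ug/mL, the lowest of the two numbers; its gap to compound 1 lies beyond the scatter.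

Compound 4 `CC(C)(C)OC(=O)Nc1nc2ccc(NC(=O)c3c(Cl)cccc3Cl)cc2s1` differs from compound 3 by tert-butoxy in place of propyl on a carbonyl carbon. Among the compounds with values here, no measured step touches the carbonyl carbon, and the single measured step is unreadable, so no direction can be drawn from the series. The expected step of a 2.0-fold higher number from compound 3 to compound 4 (0.30 log units; within the scatter) is therefore set small, within the scatter. Compound 4 is estimated at 0.02 ug/mL, between 0.005 ug/mL and 0.1 ug/mL.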

Compound 4, half-maximal effective concentration: 0.027 ug/mL
Estimate against measurement, compound 4: 1.4-fold (0.13 log units) below; the measured number falls inside the stated range.
By their numbers in this assay, from the lowest: compound 3; then compound 4; then compound 1.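

In this assay, within the data shown here, the series now has a first readable step at this carbonyl carbon, with a 2.7-fold higher number from compound 3 to compound 4 (0.43 log units; beyond the scatter) when tert-butoxy replaces propyl. The change from (propylcarbonyl)amino to (tert-butoxycarbonyl)amino therefore moves the number by a modest but real amount, so this position is not indifferent to the group it carries. The data at hand offer no measured property that bears on this step.

Among these compounds, with only two groups compared on this carbonyl carbon, no trend can be drawn. Open, as far as these compounds go, is how a longer chain, an amine or a carboxylic acid at this position would shift the number.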